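Methoxy for methyl on a second aryl ring

A few compounds are considered here, and "the series" means these few. Any claim that something is new, unique, unknown or untested is made for them only; others in the source may bear on it.

Four compounds share one core: a five-membered aromatic ring that carries a sulfur-linked chain ending in a nitro-bearing ring, and on its other side an aryl group. All of them are measured, or are to be measured, in a functional assay on MCF7 cells (Homo sapiens) for cytotoxicity, read by MTT assay, with a stated time of 48 h; a lower number here means a stronger inhibitor, a higher number a weaker inhibitor. Compound 1 has the structure `Cc1ccccc1-c1nnc(SCCn2c([N+](=O)[O-])cnc2C)o1`. In this assay compound 1 gives 15800 nM. Compound 2, `COc1ccccc1-c1nnc(SCCn2c([N+](=O)[O-])cnc2C)o1`, differs from compound 1 in one place: methoxy in place of methyl on an aromatic carbon. In this assay compound 2 gives 10800 nM. This change made a step of a 1.5-fold lower number from compound 1 to compound 2 (0.17 log units; within the scatter).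

Compound 3, `Cc1ccc(-c2nnc(SCCn3c([N+](=O)[O-])cnc3C)o2)c(O)c1`, carries a different aryl group; how it differs from compound 1 is counted here: 2-hydroxy-4-methylphenyl in place of 2-methylphenyl on an aromatic carbon. In this assay compound 3 gives 23500 nM, after a step of a 1.5-fold higher number from compound 1 to compound 3 (0.17 log units; within the scatter) and, from compound 2, a step of a 2.2-fold higher number from compound 2 to compound 3 (0.34 log units; beyond the scatter).

Compound 4, `COc1ccc(-c2nnc(SCCn3c([N+](=O)[O-])cnc3C)o2)c(O)c1`, is not yet measured. It differs from compound 3 as follows: methoxy in place of methyl on an aromatic carbon. Going by the values given here, this is the same kind of change as the one from compound 1 to compound 2, but not the same: there the methoxy enters ortho to a large group, while here it enters meta to a hydroxy group and para to a large group.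

Among the compounds with values here, the one measured example of this kind of change, from compound 1 to compound 2, gave a 1.5-fold lower number from compound 1 to compound 2 (0.17 log units; within the scatter). On that basis a step of a 1.4-fold lower number from compound 3 to compound 4 (0.14 log units; within the scatter) is expected from compound 3 to compound 4 in this assay. Compound 4 is therefore estimated at 17000 nM, with a range from 8000 nM to 36000 nM.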

Compound 4, half-maximal inhibitory concentration: 21800 nM
Estimate against measurement, compound 4: 1.3-fold (0.11 log units) below, within the range that was stated.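

In this assay, putting methoxy in place of methyl on the core of compound 3, at a place meta to a hydroxy group and para to a large group, gave a 1.1-fold lower number from compound 3 to compound 4 (0.03 log units; within the scatter). Set beside the earlier case on the core of compound 1, the two results do not differ beyond what repeated measurements would produce: the same change on two cores in this assay, a 1.5-fold lower number (0.17 log units; within the scatter) from compound 1 to compound 2 and a 1.1-fold lower number (0.03 log units; within the scatter) from compound 3 to compound 4, 1.4-fold (0.13 log units) apart, within the scatter of two such steps

This shows that, in these two pairs, the swap left the cell result within the scatter on both cores, so nothing here suggests that the second core responds differently from the first; what it does not show is that the change carries a real effect from one core to the other, since neither step can be told from the scatter, and two pairs cannot establish a rule for the whole series.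

All the compounds shown keep the same sulfur-linked chain and nitro-bearing ring, and they vary only small groups on the aryl ring. Going by these compounds, it remains open whether an amine or a carboxylic acid at the place held by the methyl or methoxy, or a longer chain between the two ring systems, would move the number beyond the scatter.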